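A few compounds are considered here, and "the series" means these few. Any claim that something is new, unique, unknown or untested is made for them only; others in the source may bear on it.

In a functional assay on A549 cells (Homo sapiens) for cytotoxicity, with a stated time of 48 h (on this read-out higher numbers stand for weaker inhibition and lower numbers for stronger inhibition), compound 2 (`C[S+]([O-])/C=C/c1cc(=O)c2ccccc2o1`) gives 1900 nM and compound 1 (`CC(C)COc1ccc2oc(/C=C/[S+](C)[O-])cc(=O)c2c1`) gives 1100 nM with the two numbers within the usual scatter of each other. Compound 3 (`CCCC(=O)Oc1ccc2oc(/C=C/[S+](C)[O-])cc(=O)c2c1`) differs from compound 2 at one place ((propylcarbonyl)oxy in place of hydrogen on an aromatic carbon) with (propylcarbonyl)oxy in place of hydrogen on an aromatic carbon. Going by the values given here, the one measured step at that carbon, hydrogen in place of isobutoxy, was small (a 1.7-fold higher number from compound 1 to compound 2 (0.24 log units; within the scatter)) so no step beyond the scatter is expected in this assay here, although no measured compound carries this group. The expected step is small (a 1.4-fold lower number from compound 2 to compound 3 (0.13 log units; within the scatter)). For compound 3 the estimated value is 1400 nM (550 nM to 3600 nM as the expected range).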

Compound 3, half-maximal inhibitory concentration: 2200 nM
For compound 3 the middle estimate is 1.6-fold (0.20 log units) below the measured one; low and high end bracket the measured number.
By their numbers in this assay, from the lowest: compounds 1, 2 and 3 (each within the scatter of the next).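

Placing (propylcarbonyl)oxy on this aromatic carbon gives a 1.2-fold higher number from compound 2 to compound 3 (0.06 log units; within the scatter) in this assay and so, like isobutoxy, brings no step beyond the scatter. Exchanging isobutyl for propylcarbonyl on the oxygen gives a 2.0-fold higher number from compound 1 to compound 3 (0.30 log units; within the scatter) and also stays within the scatter, so a carbonyl attached to that oxygen makes no readable difference here. No supporting measurement is available to explain why these numbers stay so close.

On these data alone, whether an amine, a carboxylic acid or a much longer chain on this carbon would produce a step beyond the scatter remains open. Also open, as far as these compounds go, is whether other carbons of this ring would tolerate such changes in the same way.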